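This account rests on a few compounds, and the source may have more. Where it says the series, first, only, none or still open, it means among the compounds named here.

- Compound 1 `C/C=C(\C)C(=O)O[C@H]1C=CC(=O)O[C@H]1CCC(=O)[C@H](C)O`: 26000 nM
- Compound 2 `C/C=C(\C)C(=O)O[C@H]1C=CC(=O)O[C@H]1COC(=O)[C@H](C)O`: 19000 nM

In a functional assay on NCI-H23 cells (Homo sapiens) for antiproliferative activity, read by sulforhodamine B assay, with a stated time of 48 h (on this read-out higher numbers stand for weaker inhibition and lower numbers for stronger inhibition), compound 2 gives 19000 nM, which cannot be told apart from compound 1 given the usual scatter. Compound 3 `C/C=C(\C)C(=O)O[C@H]1C=CC(=O)O[C@H]1CNC(=O)[C@H](C)O` carries ((1-hydroxyethyl)carbonyl)amino in place of ((1-hydroxyethyl)carbonyl)oxy on a saturated chain carbon bound to a saturated ring carbon. For the measured compounds named here, the only measured step at this place is a 1.4-fold lower number from compound 1 to compound 2 (0.14 log units; within the scatter). Going by the values given here, no measured compound carries the amino group, so no step beyond the scatter is expected in this assay. The estimate for compound 3 is 22000 nM, with an expected range of 9000 nM to 50000 nM. This estimate means a 1.2-fold higher number from compound 2 to compound 3 (0.06 log units; within the scatter).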

Compound 3, half-maximal inhibitory concentration: 27000 nM
Beside the measured number, compound 3's estimate is 1.2-fold (0.09 log units) below it; the measured number falls inside the stated range.
By their numbers in this assay, from the lowest: compounds 2, 1 and 3 (each within the scatter of the next).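

In this assay, ((1-hydroxyethyl)carbonyl)amino in place of ((1-hydroxyethyl)carbonyl)oxy gives a 1.4-fold higher number from compound 2 to compound 3 (0.15 log units; within the scatter), and in place of ((1-hydroxyethyl)carbonyl)methyl it gives a 1.0-fold higher number from compound 1 to compound 3 (0.02 log units; within the scatter). On a saturated chain carbon bound to a saturated ring carbon, the methyl, oxy and amino forms of this group can therefore not be told apart in this read-out. No evidence on the cause of this result is available.

All three compounds keep the 1-hydroxyethyl carbonyl part and the shared core. From the compounds shown here alone, whether a carboxylic acid or a longer chain at this place would move the number beyond the scatter remains open.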